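A few compounds are considered here, and "the series" means these few. Any claim that something is new, unique, unknown or untested is made for them only; others in the source may bear on it.

Compounds measured in a functional assay on A549 cells (Homo sapiens) for inhibition, read by MTT assay, with a stated time of 48 h; a higher number here means a weaker inhibitor, a lower number a stronger inhibitor:

- Compound 1, `COc1ccc(CNC(=O)/C=C/c2coc3cc(O)ccc3c2=O)cc1`, gives only a limit of the assay in this assay: > 100000 nM.
- Compound 2, `O=C(/C=C/c1coc2cc(O)ccc2c1=O)NCc1ccccc1`, likewise gives only a limit of the assay in this assay: > 100000 nM.
- Compound 3, `COc1cccc(NC(=O)/C=C/c2coc3cc(OC)ccc3c2=O)c1`, gives 12800 nM in this assay.

Compound 3 is thus the only one of the three to yield an actual number; the other two values are limits, namely (the limit of > 100000 nM in this assay, at which 2 of the 3 values shown sit). Going by the values given here, the single step between measured compounds, a step that the two limits leave unreadable from compound 1 to compound 2, runs between two limits and so its size cannot be read.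

Compound 4, `COc1ccc2c(=O)c(/C=C/C(=O)Nc3ccc(Cl)cc3)coc2c1`, has not yet been measured in this assay. It differs from compound 3 in one place: 4-chlorophenyl in place of 3-methoxyphenyl on an amide-type nitrogen. Among the compounds with values here, no measured step touches the group on the amide-type nitrogen, so the only step in hand, which concerns a methoxy on an aromatic carbon and is unreadable, gives no guide to the direction or size of the change from compound 3 to compound 4 in this assay.

With nothing to steer the expectation, the estimate for compound 4 in this assay stays close to the value of compound 3, with a wide range to cover the unknown: 12000 nM, between 3000 nM and 60000 nM. The step this estimate implies, a 1.1-fold lower number from compound 3 to compound 4 (0.03 log units; within the scatter), is expected to lie within the scatter.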

Compound 4, half-maximal inhibitory concentration: > 100000 nM
Compound 4 ended at the assay's limit (the forecaster's own chance of this, stated with the estimate: 25%); middle value at least 8.3-fold (0.92 log units) away from the limit.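

In this assay, going by these compounds alone, the change at this place is an at least 7.8-fold higher number from compound 3 to compound 4 (0.89 log units; beyond the scatter), the first readable step. It shows that the group on the amide-type nitrogen matters: 4-chlorophenyl there does not keep the activity seen with 3-methoxyphenyl. The value of compound 4 is a limit of the assay and not a number, so the step gives only a minimum size, and compound 4 joins the compounds that sit at this limit: the limit of > 100000 nM in this assay, at which 3 of the 4 values shown sit.

This single swap removes the methoxy group, brings in a chlorine and moves the substituent on the ring all at once, so the compounds shown cannot say which of these changes accounts for the loss of activity, or why it occurs. Also open, as far as these compounds go, is how the same core would behave in this assay with a plain phenyl or a cyclohexyl group on the amide-type nitrogen, which would show whether any substituent on an aromatic ring is needed there at all.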